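The source may report more compounds than this note shows. Statements on the series, on what has been measured and on what is new or still open speak of the compounds shown alone.

Series notes, a functional assay on Shh Light II cells (Mus musculus) for inhibition, read by a luciferase reporter; a higher number here means a weaker inhibitor, a lower number a stronger inhibitor:
- compound 1 `O=C(NC1CCC(O)CC1)N1CCC(c2nc(-c3ccc4ccccc4n3)no2)CC1`: 2700 nM
- compound 2 `O=C(NC1CC[S+]([O-])CC1)N1CCC(c2nc(-c3ccc4ccccc4n3)no2)CC1`: 850 nM
- compound 3 `O=C(Nc1ccccc1C(F)(F)F)N1CCC(c2nc(-c3ccc4ccccc4n3)no2)CC1`: 700 nM

Compound 3, at 700 nM, stands level with compound 2 and clear of compound 1. Compound 4 `O=C(Nc1cccnc1Cl)N1CCC(c2nc(-c3ccc4ccccc4n3)no2)CC1` is the next to be read, with the change 2-chloropyridin-3-yl in place of 2-(trifluoromethyl)phenyl on an amide-type nitrogen.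

All three measured steps fall at this same place. Two are modest, a 3.2-fold lower number from compound 1 to compound 2 (0.50 log units; beyond the scatter) and a 3.9-fold lower number from compound 1 to compound 3 (0.59 log units; beyond the scatter), and the third is a 1.2-fold lower number from compound 2 to compound 3 (0.08 log units; within the scatter). None of them exchanges one aromatic group for another, so they give only a rough size for changes here and no firm direction. Even the swap of 2-(trifluoromethyl)phenyl for a non-aromatic ring in compound 2 left no separation from compound 3, so no step beyond the scatter is expected in this assay.

The expected step is a 1.3-fold higher number from compound 3 to compound 4 (0.11 log units; within the scatter).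

The estimate for compound 4 is 900 nM, with an expected range of 300 nM to 2700 nM.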

Compound 4, half-maximal inhibitory concentration: 1600 nM
The estimate for compound 4 lay 1.8-fold (0.25 log units) below the measured number; the range from low to high includes it.
By their numbers in this assay, from the lowest: compounds 3, 2, 4 and 1 (each within the scatter of the next, the first and the last beyond it).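

In this assay, going by these compounds alone, this is the first exchange of one aromatic group for another on the amide-type nitrogen, and it gives a 2.3-fold higher number from compound 3 to compound 4 (0.36 log units; beyond the scatter) as a modest step beyond the scatter, so the aromatic group here is not interchangeable. Compound 4 stays within the scatter of both non-aromatic compounds, with a 1.9-fold higher number from compound 2 to compound 4 (0.27 log units; within the scatter) and a 1.7-fold lower number from compound 1 to compound 4 (0.23 log units; within the scatter) as the steps, so an aromatic ring at this place does not by itself separate a compound from compound 1, though compound 3 does stand clear of compound 1. No measurement on hand explains the step.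

The exchange alters the ring and its substituent together, so their shares remain unseparated. A 2-chlorophenyl group, or an amine or carboxylic acid on the aromatic ring, would remain to be read in this series.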